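Triazole aryl substitution: notes on compounds 2 and 3

A few compounds are considered here, and "the series" means these few. Any claim that something is new, unique, unknown or untested is made for them only; others in the source may bear on it.

compound 1 `Cc1c(O)ccc2c1[C@H](Cn1cc(-c3ccc(Cl)cc3)nn1)[C@@]13CC(=O)[C@@](C)(CC[C@@H]21)C3`: in a functional assay on SW480 cells (Homo sapiens) for cytotoxicity, read by MTT assay, with a stated time of 4 days (a lower number here means a stronger inhibitor, a higher number a weaker inhibitor), compound 1 gives > 20000 nM, which is a limit of the assay, not a number.
compound 2 `C=C1C(=O)[C@]23C[C@@]1(O)CC[C@H]2c1ccc(O)c(C)c1[C@@H]3Cn1cc(-c2ccccc2)nn1`: in this assay compound 2 gives 260 nM.

For the measured compounds named here, compound 2 holds the only numeric value in this assay; the other value shown is a limit (the limit of > 20000 nM in this assay, at which 1 of the 2 values shown sits). Compound 3 `C=C1C(=O)[C@]23C[C@@]1(O)CC[C@H]2c1ccc(O)c(C)c1[C@@H]3Cn1cc(-c2ccc(C(F)(F)F)cc2)nn1` differs from compound 2 by trifluoromethyl in place of hydrogen on an aromatic carbon. Going by the values given here, no step between measured compounds is available for this change, so no shift beyond the usual scatter is expected in this assay. Compound 3 is estimated at 400 nM, with a range from 150 nM to 2000 nM. The expected step of a 1.5-fold higher number from compound 2 to compound 3 (0.19 log units; within the scatter) is taken to lie within the scatter.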

Compound 3, half-maximal inhibitory concentration: 370 nM
Beside the measured number, compound 3's estimate is 1.1-fold (0.03 log units) above it; measured number inside the range.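

In this assay, trifluoromethyl in place of hydrogen on the aromatic carbon para to a large group gives a 1.4-fold higher number from compound 2 to compound 3 (0.15 log units; within the scatter), so this position takes the change without a shift beyond the scatter. For the compounds shown here, this is the first step that can be read at this position, as compound 1 differs from compound 2 in more than one place. No measurement shown gives a reason for this step.

A single replacement does not define a trend at this position. From the compounds shown here alone, whether an amine, a carboxylic acid or a longer alkyl chain on the same carbon would also stay within the scatter remains open.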